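This account rests on a few compounds, and the source may have more. Where it says the series, first, only, none or still open, it means among the compounds named here.

Measured so far:

Compound 1, `Cc1cccc(-c2n[nH]c(-c3ccccc3)n2)c1`, in a functional assay on the whole organism (Cricetulus griseus) with Cricetinae gen. sp. as the target; a lower number here means that less compound is needed, a higher number that more compound is needed for the effect: > 20 mg/kg, which is a limit of the assay rather than a number.
Compound 2, `CCc1ccccc1-c1n[nH]c(-c2cccc(OC)c2)n1`, in this assay: 0.04 mg/kg.
Compound 3, `CCCCc1ccccc1-c1n[nH]c(-c2cccc(OC)c2)n1`, in this assay: 12 mg/kg.

All three share one core and differ only in the groups hanging from its two benzene rings. Within the data shown here, compound 2 has the lowest of the two numbers obtained; the only other number belongs to compound 3, and the step from one to the other is large: a 300-fold higher number from compound 2 to compound 3 (2.48 log units; beyond the scatter). Among the measured compounds shown here, the value of compound 1 sits at the limit of > 20 mg/kg in this assay, at which 1 of the 3 values shown sits, so it tells only that more compound than the cap was needed.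

Compound 4, `C=CCOc1cccc(-c2nc(-c3ccccc3CC)n[nH]2)c1`, is compound 2 altered at the other ring: vinyl in place of hydrogen on a saturated chain carbon bound to an oxygen on an aromatic ring. For the measured compounds named here, no measured step touches this position; the single step on record, from compound 2 to compound 3, concerns a chain on the other benzene ring. Going by the values given here, that step is the only guide, and it shows that adding carbons to compound 2 can raise the number sharply. Because of a 300-fold higher number from compound 2 to compound 3 (2.48 log units; beyond the scatter) a rise is expected here too, though smaller, since the carbons enter at a different place; the expected step from compound 2 to compound 4 is a 7.5-fold higher number from compound 2 to compound 4 (0.88 log units; beyond the scatter). Compound 4 is therefore estimated at 0.3 mg/kg, within a range from 0.04 mg/kg to 4 mg/kg.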

Compound 4, dose for half-maximal effect: 0.12 mg/kg
The estimate for compound 4 lay 2.5-fold (0.40 log units) above the measured number; the measured number falls inside the stated range.
By their numbers in this assay, from the lowest: compound 2; then compound 4; then compound 3. At a limit, above all of these: compound 1.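

Among these compounds, compound 4 gives the first reading at the oxygen-bearing end of the molecule, and in this assay changing methoxy to allyloxy gives a 3.0-fold higher number from compound 2 to compound 4 (0.48 log units; beyond the scatter), a modest rise that is still beyond the scatter. The number for compound 4 remains low at 0.12 mg/kg, so this position accepts vinyl in place of hydrogen on the saturated chain carbon bound to the oxygen without the large loss seen on the other benzene ring, where the earlier change gave a 300-fold higher number from compound 2 to compound 3 (2.48 log units; beyond the scatter). The compounds shown therefore tell that extending a chain does not carry the same cost at both places, but nothing among the available measurements explains the difference in size between these two steps.

Still open, from the compounds shown here alone, is whether a longer chain on this oxygen, such as butoxy, would raise the number further, or whether the rise seen with allyloxy stays modest. Going by these compounds, it is also open how an amine or a carboxylic acid at the end of that chain would fare in this position.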